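Aryl Swap on the Carbonyl in a Weakly Cytotoxic Series

A few compounds are considered here, and "the series" means these few. Any claim that something is new, unique, unknown or untested is made for them only; others in the source may bear on it.

In a functional assay on MCF7 cells (Homo sapiens) for cytotoxicity, read by MTT assay, with a stated time of 48 h (a higher number here means a weaker inhibitor, a lower number a stronger inhibitor), compound 1 `COc1cc(-c2nnc3n2NC(c2ccco2)C(C(=O)c2ccccc2F)S3)cc(OC)c1OC` gives 94800 nM. Compound 2 `COc1cc(-c2nnc3n2NC(c2ccco2)C(C(=O)c2ccc(Cl)cc2)S3)cc(OC)c1OC` returns only the limit of this assay, > 100000 nM. Compound 3 `COc1cc(-c2nnc3n2NC(c2ccco2)C(C(=O)c2ccc([N+](=O)[O-])cc2)S3)cc(OC)c1OC` likewise returns only a limit, > 100000 nM. Compound 3 therefore stands at the limit of > 100000 nM in this assay, at which 2 of the 3 values shown sit. The steps of an at least 1.0-fold higher number from compound 1 to compound 2 (0.02 log units; that floor lies within the scatter) and an at least 1.0-fold higher number from compound 1 to compound 3 (0.02 log units; that floor lies within the scatter) both sit at a floor within the scatter, while a step that the two limits leave unreadable from compound 2 to compound 3. Compound 4 `COc1cc(-c2nnc3n2NC(c2ccco2)C(C(=O)c2ccc(-c4ccccc4)cc2)S3)cc(OC)c1OC` differs from compound 3 by phenyl in place of nitro on an aromatic carbon. Among the measured compounds shown here, none of the measured steps exchanges the ring itself, and the two steps touching the carbonyl substituent show no movement beyond the scatter. The writer therefore expects a number no higher from compound 3 to compound 4 (the limit leaves the size open). For compound 4 the estimate is 100000 nM, within 30000 nM to 300000 nM, with a fair chance of only a limit again.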

Compound 4, half-maximal inhibitory concentration: > 100000 nM
Compound 4: no number, only a limit; the forecaster's own chance of this, stated with the estimate: 60%; the middle value sits exactly at the limit.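

In this assay, phenyl on this aromatic carbon, a six-membered aromatic ring of carbon only, ends at the same limit as nitro and chloro, so the larger group brings no readable value here either: the limit of > 100000 nM in this assay, at which 3 of the 4 values shown sit.

The series shows an at least 1.0-fold higher number from compound 1 to compound 4 (0.02 log units; that floor lies within the scatter), and the steps among compound 2, compound 3 and compound 4 cannot be read, as all three values are limits.

From the compounds shown here alone, whether an amine or a carboxylic acid in this place would give a number under the limit stays open.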